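The compounds below may be only part of what the source reports. "The series", "measured", "known", "first", "only" and "open" are said of these compounds alone.

For the measured compounds named here, in an ADME assay on MDBK cells (Bos taurus) for cytotoxicity, read by MTT assay, with a stated time of 96 h (on this read-out higher numbers stand for lower toxicity in this test and lower numbers for higher toxicity in this test), three compounds have numbers so far. Compound 1 `CCCC[C@H]1CC[C@H](c2ccc(NC(=S)Nc3cccc(C(F)(F)F)c3)cc2)CC1` gives 10000 nM, compound 2 `COc1cccc(NC(=S)Nc2cccc(C(F)(F)F)c2)c1` gives 52000 nM and compound 3 `FC(F)(F)c1cccc(NC(=S)Nc2ccccc2)c1` gives 49000 nM. Compound 3 cannot be told apart from compound 2 and stands higher than compound 1.

The next compound, compound 4 `CC(=O)NC(=S)Nc1cccc(C(F)(F)F)c1`, carries acetyl in place of phenyl on an amide-type nitrogen whose other neighbour is the thiocarbonyl carbon: acetyl in place of phenyl on an amide-type nitrogen.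

Going by the values given here, no measured step touches this nitrogen, so the guidance is indirect. Hydrogen in place of 4-butylcyclohexyl on an aromatic carbon gave a 4.9-fold higher number from compound 1 to compound 3 (0.69 log units; beyond the scatter), a modest step beyond the scatter. Hydrogen in place of methoxy on an aromatic carbon gave a 1.1-fold lower number from compound 2 to compound 3 (0.03 log units; within the scatter), within the scatter. Loss of the ring-bearing group from compound 1 is thus the only change so far that moved the number, and it moved it upward. Compound 4 also gives up a ring, but a smaller piece leaves than in that step, and a new group enters. In this assay, only a small upward move is expected, with the estimated step being a 1.6-fold higher number from compound 3 to compound 4 (0.21 log units; within the scatter). For compound 4 the expected value is 80000 nM, with an estimated range of 35000 nM to 170000 nM.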

Compound 4, half-maximal cytotoxic concentration: > 100000 nM
Compound 4 ended at the assay's limit; the forecaster's own chance of this, stated with the estimate: 25%; middle value at least 1.2-fold (0.09 log units) away from the limit.
By their numbers in this assay, from the lowest: compound 1; then compounds 3 and 2 (each within the scatter of the next). At a limit, above all of these: compound 4.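

In this assay, for the compounds shown here, the step at the amide-type nitrogen whose other neighbour is the thiocarbonyl carbon, with acetyl in place of phenyl, is an at least 2.0-fold higher number from compound 3 to compound 4 (0.30 log units; that floor lies within the scatter), the first reading at this nitrogen, as both earlier steps sat on an aromatic carbon. Compound 4 stands at a limit and not at a number: the limit of > 100000 nM in this assay, at which 1 of the 4 values shown sits. From the compounds shown here alone, the step is therefore a floor whose true size stays unknown and which by itself does not clear the scatter, but it does show that the phenyl ring on this nitrogen can leave, with acetyl entering, without any fall in the number, so lower toxicity in this test is not tied to that ring.

The change removes a ring and adds a carbonyl in one move, leaving open which of the two goes with the step, and whether the size of the group matters more than its kind. A plain methyl or a longer chain such as butyl on this nitrogen would separate these readings, and any such compound with a value short of the limit would give a step of known size.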